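Swapping cyclopentyl for isopropyl on an aromatic nitrogen

The compounds below may be only part of what the source reports. "The series", "measured", "known", "first", "only" and "open" are said of these compounds alone.

Measured so far:
- compound 1 `CN1CCN(c2nc(Cl)nc3c2ncn3Cc2ccc(C(=O)Nc3ccccc3N)cc2)CC1`: 55.1%
- compound 2 `CC(C)n1cnc2c(Nc3cccc(Cl)c3)nc(NCOCc3ccc(C(=O)Nc4ccccc4N)cc3)nc21`: 43.2%
- compound 3 `Nc1ccccc1NC(=O)/C=C/c1ccc(COCNc2nc(Nc3cccc(Cl)c3)c3ncn(C4CCCC4)c3n2)cc1`: 46.1%

All three numbers come from a functional assay on NCI-H460 cells (Homo sapiens) for antiproliferative activity, read by CCK-8 assay, with a stated time of 72 h, tested at 8 uM; on this read-out higher numbers stand for a stronger effect at the one concentration tested and lower numbers for a weaker effect. Compound 3 gives 46.1% in this assay, which is the second highest of the three numbers; compound 2 sits below it and compound 1 above it, and both gaps fall within the usual scatter of this kind of measurement, so the three values cannot be told apart with confidence.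

Compound 4 `CC(C)n1cnc2c(Nc3cccc(Cl)c3)nc(NCOCc3ccc(/C=C/C(=O)Nc4ccccc4N)cc3)nc21` has not yet been measured. It differs from compound 3 in a single place: isopropyl in place of cyclopentyl on an aromatic nitrogen. Compound 2 already carries isopropyl on the same aromatic nitrogen, and its value 43.2% lies close to that of compound 3. On that basis the step in this assay is expected to be small, with no change beyond the scatter. Compound 4 is expected to give 44%, with a likely range from 30% to 58%, corresponding to an expected step of a number 2.1 percentage points lower from compound 3 to compound 4 (within the scatter).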

Compound 4, a percentage reported as inhibition, at one concentration (the size of the read-out at that concentration, not a potency): 61.1%
The estimate for compound 4 lay 17.1 percentage points below the measured number; measured number above the stated range.
By their numbers in this assay, from the lowest: compounds 2, 3, 1 and 4 (each within the scatter of the next, the first and the last beyond it).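

In this assay, isopropyl in place of cyclopentyl on the aromatic nitrogen gives a number 15 percentage points higher from compound 3 to compound 4 (beyond the scatter) and so shows that the group at this position can change the read-out by more than the usual scatter. With isopropyl held fixed, 2-((2-aminophenyl)carbamoyl)ethenyl in place of (2-aminophenyl)carbamoyl on an aromatic carbon gives a number 17.9 percentage points higher from compound 2 to compound 4 (beyond the scatter), so a second place on the molecule also matters in this series. No available measurement explains either step.

The compounds shown do not reveal whether isopropyl would also outperform cyclopentyl in a compound carrying (2-aminophenyl)carbamoyl on that aromatic carbon. On these data alone, how an ethyl group or a longer chain ending in an amine would behave on the same aromatic nitrogen also remains open.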